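The source may report more compounds than this note shows. Statements on the series, on what has been measured and on what is new or still open speak of the compounds shown alone.

Two compounds share one core and differ only in the group on an amine nitrogen in a ring. Compound 1 `O=C(NCCCN1CCN(c2ccc(Br)cc2)CC1)NN(Cc1ccccc1)c1ccccc1` carries 4-bromophenyl there, and in an assay on CHO cells for displacement of a labelled ligand from D(4) dopamine receptor (Homo sapiens), read by radioligand binding (on this read-out higher numbers stand for weaker inhibition and lower numbers for stronger inhibition), compound 1 gives 14 nM. Compound 2 `O=C(NCCCN1CCN(c2ncccn2)CC1)NN(Cc1ccccc1)c1ccccc1` carries pyrimidin-2-yl at the same place, and in this assay compound 2 gives 18 nM. Of the two numbers compound 2 stands at the top, but the step of a 1.3-fold higher number from compound 1 to compound 2 (0.11 log units; within the scatter) lies within the scatter, so the two compounds cannot be told apart on what has been measured. Compound 3 `O=C(NCCCN1CCN(c2ccc(I)cc2)CC1)NN(Cc1ccccc1)c1ccccc1` has not been measured yet. It differs from compound 2 by 4-iodophenyl in place of pyrimidin-2-yl on an amine nitrogen in a ring, so the change runs back from pyrimidin-2-yl to a 4-halophenyl, with 4-iodophenyl now standing where compound 1 had 4-bromophenyl. For the measured compounds named here, the only step that bears on this is the one from compound 1 to compound 2, which stayed within the scatter, and nothing here shows what swapping the bromine for iodine does. For this assay no step beyond the scatter is therefore expected. The estimate for compound 3 is 13 nM, with a range from 5 nM to 32 nM, which means an expected step of a 1.4-fold lower number from compound 2 to compound 3 (0.14 log units; within the scatter).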

Compound 3, inhibition constant: 21 nM
Beside the measured number, compound 3's estimate is 1.6-fold (0.21 log units) below it; the measured number falls inside the stated range.
By their numbers in this assay, from the lowest: compounds 1, 2 and 3 (each within the scatter of the next).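

At this place, on an amine nitrogen in a ring, this assay now holds three groups that cannot be told apart: the step of a 1.2-fold higher number from compound 2 to compound 3 (0.07 log units; within the scatter) shows that even a full exchange of ring type leaves the compounds within the scatter, with 4-iodophenyl, a ring of carbon only with 0 hydrogen-bond acceptors, entering for pyrimidin-2-yl, which has 2 of them. For the compounds shown here, the exchange of halogen on the aromatic carbon, on which the earlier compounds were silent, reads the same way, since the step of a 1.5-fold higher number from compound 1 to compound 3 (0.18 log units; within the scatter) does not separate iodo from bromo. Across these three compounds, then, neither the ring nitrogens nor the identity of the halogen goes with a readable difference, and no measurement here explains why.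

Open, going by these compounds, is whether this holds for groups of another kind on that nitrogen, such as a plain methyl, a chloro or fluoro on the phenyl ring, or a phenyl ring carrying a carboxylic acid. Also open, on these data alone, is whether a longer chain in the shared core would leave these groups just as hard to tell apart.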